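The compounds below may be only part of what the source reports. "The series", "measured", "known", "first", "only" and "open" are said of these compounds alone.

Compound 1 `Cc1ccc(C(F)(F)F)cc1COc1cc(NC(=O)c2ccc(Br)cc2)ccc1N(C)S(C)(=O)=O` and compound 2 `COc1ccc(C(=O)Nc2ccc(N(C)S(C)(=O)=O)c(OCc3cc(C(F)(F)F)ccc3C)c2)cc1` share one core. In a functional assay on SK-BR-3 cells (Homo sapiens) for antiproliferative activity, read by MTT assay, with a stated time of 48 h (on this read-out lower numbers stand for stronger inhibition and higher numbers for weaker inhibition), compound 1 gives 9490 nM, while compound 2 gives 2030 nM. The change between them, (methoxy in place of bromo on an aromatic carbon), produced a 4.7-fold lower number from compound 1 to compound 2 (0.67 log units; beyond the scatter). Compound 3 `COc1ccc(OC)c(COc2cc(NC(=O)c3ccc(Br)cc3)ccc2NS(C)(=O)=O)c1` rests on a different core; how the two cores differ is not broken down here. In this assay compound 3 gives 9.58 nM, the lowest of the three numbers. Compound 4 `COc1ccc(C(=O)Nc2ccc(NS(C)(=O)=O)c(OCc3cc(OC)ccc3OC)c2)cc1` carries the same change as before, (methoxy in place of bromo on an aromatic carbon), now made on the core of compound 3. A step of similar size is expected because the earlier step of a 4.7-fold lower number from compound 1 to compound 2 (0.67 log units; beyond the scatter) was modest, though the already low value of compound 3 9.58 nM leaves room for a smaller gain on this core. Compound 4 is therefore expected to give 3.5 nM in this assay, most likely between 1 nM and 15 nM, which means an expected step of a 2.7-fold lower number from compound 3 to compound 4 (0.44 log units; beyond the scatter).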

Compound 4, half-maximal inhibitory concentration: 13.4 nM
For compound 4 the middle estimate is 3.8-fold (0.58 log units) below the measured one, within the range that was stated.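

On the core of compound 3, methoxy in place of bromo gave a 1.4-fold higher number from compound 3 to compound 4 (0.15 log units; within the scatter) in this assay and so no readable change. The same swap therefore did not carry the same effect from one core to the other: the same change on two cores in this assay, a 4.7-fold lower number (0.67 log units; beyond the scatter) from compound 1 to compound 2 and a 1.4-fold higher number (0.15 log units; within the scatter) from compound 3 to compound 4, 6.5-fold (0.82 log units) apart, beyond the scatter of two such steps

Going by these compounds alone, with only two pairs, this shows that a step seen on one core need not predict the step on another, but it does not show which difference between the cores is responsible or how the swap would behave on a third core.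

Only bromo and methoxy appear at this position on the two cores. From the compounds shown here alone, whether a chlorine, a nitrile or an amine there would behave alike on both cores remains open.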